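The compounds below may be only part of what the source reports. "The series", "measured", "known", "first", "only" and "open" are said of these compounds alone.

Measured so far:
compound 1 `COc1ccc(C(=O)/C=C/c2cc(-c3cc(OC)c(OC)c(OC)c3)n3nc(-c4ccccc4)cc3n2)cc1OC` — in an ADME assay on HEK293 cells (Homo sapiens) for antiproliferative activity, read by MTT assay, with a stated time of 24 h (a higher number here means a weaker inhibitor, a lower number a stronger inhibitor), compound 1 gives 81700 nM
compound 2 `COc1ccc(-c2cc(/C=C/C(=O)c3ccc(OC)c(OC)c3)nc3cc(-c4ccccc4)nn23)cc1` — compound 2 gives 48500 nM

The two numbers lie within the scatter of each other, as the step of a 1.7-fold lower number from compound 1 to compound 2 (0.23 log units; within the scatter) shows. Compound 3 `COc1cc(-c2cc(/C=C/C(=O)c3ccc(C)cc3)nc3cc(-c4ccccc4)nn23)cc(OC)c1OC` differs from compound 1 at the other end of the molecule: 4-methylphenyl in place of 3,4-dimethoxyphenyl on a carbonyl carbon. Among the compounds with values here, no measured step touches that carbonyl side, and the one step that exists, a 1.7-fold lower number from compound 1 to compound 2 (0.23 log units; within the scatter), is within the scatter, so no change beyond the scatter is expected; the estimated step is a 1.0-fold lower number from compound 1 to compound 3 (0.01 log units; within the scatter). Compound 3 is therefore estimated at 80000 nM, in the range 30000 nM to 200000 nM.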

Compound 3, half-maximal inhibitory concentration: 50400 nM
Compound 3: middle estimate off by 1.6-fold (0.20 log units), on the high side; measured number inside the range.
By their numbers in this assay, from the lowest: compounds 2, 3 and 1 (each within the scatter of the next).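

The carbonyl side now has a measured step of its own: in this assay, 4-methylphenyl in place of 3,4-dimethoxyphenyl on a carbonyl carbon gives (a 1.6-fold lower number from compound 1 to compound 3 (0.21 log units; within the scatter)). Losing both hydrogen-bond acceptors of the leaving group therefore keeps the number within the scatter at this position. No available evidence accounts for this result. The compounds shown leave open what a non-aromatic group on this carbonyl carbon, such as an amine or a longer chain, would give. On these data alone, a carboxylic acid on the 4-methylphenyl ring also remains open.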